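Trimming the Ethoxy Group on the Shared Core

This account rests on a few compounds, and the source may have more. Where it says the series, first, only, none or still open, it means among the compounds named here.

Compound 1, `CCOc1nc(CC)n2c1C(CCc1ccc(C(F)(F)F)cc1)N([C@@H](C(=O)NC)c1ccccc1)CC2`: 3980 nM
Compound 2, `CNC(=O)[C@@H](c1ccccc1)N1CCn2c(C)nc(Cl)c2[C@@H]1CCc1ccc(C(F)(F)F)cc1`: 90 nM

Both compounds were tested in a functional assay on CHO cells for antagonist activity at Orexin/Hypocretin receptor type 1 (Homo sapiens), read by FLIPR and calcium flux; on this read-out higher numbers stand for weaker inhibition and lower numbers for stronger inhibition. Compound 1 stands at the higher of the two numbers, the weaker inhibitor; compound 2 lies well below it, a gap beyond the scatter. Compound 3, `CCc1ncc2n1CCN([C@@H](C(=O)NC)c1ccccc1)C2CCc1ccc(C(F)(F)F)cc1`, is not yet measured. It differs from compound 1 by hydrogen in place of ethoxy on an aromatic carbon. Going by the values given here, no pair of measured compounds isolates this change: compound 2 differs from compound 1 in more than one place, so its low number cannot be assigned to any single group. The ethoxy is the sole substituent removed, and compound 1 is the weaker of the two known points, so the step from compound 1 to compound 3 is expected to be a 2.7-fold lower number from compound 1 to compound 3 (0.42 log units; beyond the scatter) toward stronger inhibition, possibly not beyond the scatter. Compound 3 is therefore estimated at 1500 nM, within a range from 400 nM to 6000 nM.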

Compound 3, half-maximal inhibitory concentration: 10000 nM
Estimate against measurement, compound 3: 6.7-fold (0.82 log units) below, outside the stated range (above it).
By their numbers in this assay, from the lowest: compound 2; then compound 1; then compound 3.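

With hydrogen in place of ethoxy on this aromatic carbon, this assay gives a 2.5-fold higher number from compound 1 to compound 3 (0.40 log units; beyond the scatter) and thus modestly weaker inhibition. Going by these compounds alone, this is the first pair of measured compounds to isolate the position, and it shows that taking the ethoxy away does not recover inhibition: although compound 1 is a weak inhibitor, the unsubstituted carbon of compound 3 does somewhat worse. Nothing available here speaks to why the step runs in this direction.

As far as these compounds go, it remains open whether a methoxy group, a longer alkoxy chain or an amine on this aromatic carbon would give a lower number than ethoxy or hydrogen does. The low number of compound 2 also stays unassigned, since it differs from both other compounds in more than one place.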